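Swapping the aryl group on the tetrazole of a FAAH inhibitor

The source may report more compounds than this note shows. Statements on the series, on what has been measured and on what is new or still open speak of the compounds shown alone.

Three compounds have been measured in an assay on microsomes from brain for inhibition of Fatty-acid amide hydrolase 1 (Rattus norvegicus), read by fluorescence and HPLC, with a stated time of 60 min; a higher number here means a weaker inhibitor, a lower number a stronger inhibitor:
compound 1 `CCCCCCCCc1ccc(OCC(=O)Cn2nnc(-c3ccc(Cl)cc3)n2)cc1`, 35 nM
compound 2 `CCCCCCCCc1ccc(OCC(=O)Cn2nnc(-c3ccc(C(=O)OC)cc3)n2)cc1`, 29 nM
compound 3 `CCCCCCCCc1ccc(OCC(=O)Cn2nnc(-c3cccc(S(=O)(=O)N(C)C)c3)n2)cc1`, 420 nM

Compound 3 gives the highest number of the three, which here means the weakest inhibition. Compound 1 and compound 2 lie close together, a 1.2-fold lower number from compound 1 to compound 2 (0.08 log units; within the scatter), so between those two nothing can be ordered.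

Compound 4 `CCCCCCCCc1ccc(OCC(=O)Cn2nnc(-c3ccccn3)n2)cc1` is not yet measured. Compared with compound 3 the change is pyridin-2-yl in place of 3-(dimethylsulfamoyl)phenyl on an aromatic carbon. The aryl group on the shared core thus becomes smaller and loses its sulfonamide.

Among the compounds with values here, the steps that bear on this are the two that put the 3-(dimethylsulfamoyl)phenyl group in: a 12-fold higher number from compound 1 to compound 3 (1.08 log units; beyond the scatter) and a 14-fold higher number from compound 2 to compound 3 (1.16 log units; beyond the scatter). Both were large and both went toward weaker inhibition. Taking that group out again is therefore expected to move the number back down in this assay, toward the range of compound 1 and compound 2. Since pyridin-2-yl is a new group, not tested in any measured compound, the size of the return is uncertain, and a somewhat smaller gain than a full reversal is a cautious guess.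

The estimate for compound 4 is 60 nM, with a range from 15 nM to 250 nM, an expected step of a 7.0-fold lower number from compound 3 to compound 4 (0.85 log units; beyond the scatter).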

Compound 4, half-maximal inhibitory concentration: 18 nM
The estimate for compound 4 lay 3.3-fold (0.52 log units) above the measured number; the measured number falls inside the stated range.
By their numbers in this assay, from the lowest: compounds 4, 2 and 1 (each within the scatter of the next); then compound 3.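

In this assay, putting pyridin-2-yl in place of 3-(dimethylsulfamoyl)phenyl gives a 23-fold lower number from compound 3 to compound 4 (1.37 log units; beyond the scatter), so the large loss seen with compound 3 does not appear with every new aryl group at this position. Compound 4 also lands level with the two substituted phenyl compounds, with a 1.6-fold lower number from compound 2 to compound 4 (0.21 log units; within the scatter) and a 1.9-fold lower number from compound 1 to compound 4 (0.29 log units; within the scatter), so among these three no order can be drawn, and a ring with one nitrogen and no further group serves here as well as a ring carrying a chloro or a methoxycarbonyl group. No measurement on hand explains why compound 3 alone stands apart from the other three.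

The compounds shown leave open whether the weaker inhibition of compound 3 belongs to the sulfonamide itself or to where it sits on the ring, a question that a 4-(dimethylsulfamoyl)phenyl group on the shared core could help settle. They also leave open whether the ring nitrogen of compound 4 matters at all, which a plain phenyl group in its stead would test, and how a carboxylic acid on the aryl ring would fare.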